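This account rests on a few compounds, and the source may have more. Where it says the series, first, only, none or still open, it means among the compounds named here.

Compound 1 `CNc1nc(-c2cc(OC)c(OC)c(OC)c2)c(-c2ccc(C(F)(F)F)cc2)s1` gives 3400 nM
Compound 2 `COc1cc(-c2nc(N(C)C)sc2-c2ccc(C(F)(F)F)cc2)cc(OC)c1OC` gives > 10000 nM
Compound 3 `COc1cc(-c2nc(C)sc2-c2ccc(C)cc2)cc(OC)c1OC` gives 1100 nM
Compound 4 `COc1cc(-c2nc(C)sc2-c2ccc(C(F)(F)F)cc2)cc(OC)c1OC` has not yet been measured

In a functional assay on HeLa cells (Homo sapiens) for antiproliferative activity, read by MTT assay, with a stated time of 72 h (a lower number here means a stronger inhibitor, a higher number a weaker inhibitor), compound 3 has the lowest number shown at 1100 nM and compound 1 is the nearest at 3400 nM on the higher side. Compound 2 reads > 10000 nM as a limit and not a number. Compound 4 differs from compound 3 in one place, with trifluoromethyl in place of methyl on an aromatic carbon. Among the measured compounds shown here, the only measured step of an at least 2.9-fold higher number from compound 1 to compound 2 (0.46 log units; beyond the scatter) is a change on a nitrogen, not on this aromatic carbon, so it gives no direct size. Compound 1 carries the same trifluoromethyl and reads 3400 nM but also differs from compound 3 at a second place, so only a modest rise to a higher number is expected. The expected step is a 2.3-fold higher number from compound 3 to compound 4 (0.36 log units; beyond the scatter) in this assay and remains uncertain. Compound 4 is estimated at 2500 nM with an expected range from 800 nM to 7000 nM for the coming measurement.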

Compound 4, half-maximal inhibitory concentration: 3830 nM
Beside the measured number, compound 4's estimate is 1.5-fold (0.19 log units) below it, within the range that was stated.
By their numbers in this assay, from the lowest: compound 3; then compounds 1 and 4 (each within the scatter of the next). At a limit, above all of these: compound 2.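

In this assay, trifluoromethyl in place of methyl on the aromatic carbon para to a large group gives a 3.5-fold higher number from compound 3 to compound 4 (0.54 log units; beyond the scatter), the first direct measure of this change. Methyl in place of methylamino gives a 1.1-fold higher number from compound 1 to compound 4 (0.05 log units; within the scatter), so this swap on the shared core shows no change beyond the scatter. Compound 2 stands at a limit, not a number, and methyl in place of dimethylamino gives an at least 2.6-fold lower number from compound 2 to compound 4 (0.41 log units; beyond the scatter). The compounds shown leave open how a methoxy group or a single chlorine atom on that aromatic carbon would read.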